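This account rests on a few compounds, and the source may have more. Where it says the series, first, only, none or still open, it means among the compounds named here.

Measured compounds in an assay for binding affinity to dual specificity mitogen-activated protein kinase kinase 4 (Homo sapiens), read by KINOMEscan, tested at 100 nM; on this read-out lower numbers stand for a stronger effect and higher numbers for a weaker effect at the one concentration tested:
- compound 1, `CCCS(=O)(=O)Nc1ccc(F)c(C(=O)c2n[nH]c3ncc(-c4ccccc4)cc23)c1F`, gives 2.4%
- compound 2, `CCCS(=O)(=O)Nc1ccc(F)c(C(=O)c2n[nH]c3ncc(-c4ccccc4F)cc23)c1F`, gives 2%
- compound 3, `CCCS(=O)(=O)Nc1ccc(F)c(C(=O)c2n[nH]c3ncc(-c4ccc(Cl)cc4Cl)cc23)c1F`, gives 22%

Compound 3 stands highest of the three numbers in this assay: its nearest neighbour is compound 1, a number a number 19.6 percentage points higher from compound 1 to compound 3 (beyond the scatter), and the furthest is compound 2, a number 20 percentage points higher from compound 2 to compound 3 (beyond the scatter). Compound 1 and compound 2 lie within the scatter of each other, a number 0.4 percentage points lower from compound 1 to compound 2 (within the scatter).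

Compound 4, `CCCS(=O)(=O)Nc1ccc(F)c(C(=O)c2n[nH]c3ncc(-c4ccc(C(=O)O)cc4)cc23)c1F`, differs from compound 3 in one place: 4-carboxyphenyl in place of 2,4-dichlorophenyl on an aromatic carbon.

Going by the values given here, two measured steps bear on this change. Both replace a smaller ring substituent with the 2,4-dichlorophenyl group and both raise the number by a modest amount beyond the scatter. Going the other way, from the 2,4-dichlorophenyl group of compound 3 to a ring carrying a single substituent, the reverse of those steps is the natural guide, but no measured compound carries a 4-carboxyphenyl group, so the size of its effect is not known.

Compound 4 is therefore expected to show a number lower than compound 3, estimated at 8%, a step of a number 14 percentage points lower from compound 3 to compound 4 (beyond the scatter), with a range from 1% to 35%.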

Compound 4, a percentage reported as activity, at one concentration (the size of the read-out at that concentration, not a potency): 0.1%
The estimate for compound 4 lay 7.9 percentage points above the measured number, outside the stated range (below it).
By their numbers in this assay, from the lowest: compounds 4, 2 and 1 (each within the scatter of the next); then compound 3.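

In this assay, a carboxy group on the phenyl ring at this position keeps the number low, whereas the 2,4-dichlorophenyl group does not, with a number 21.9 percentage points lower from compound 3 to compound 4 (beyond the scatter). The added carboxy group shows no difference that can be told from the plain phenyl ring or the 2-fluorophenyl ring, with a number 2.3 percentage points lower from compound 1 to compound 4 (within the scatter) and a number 1.9 percentage points lower from compound 2 to compound 4 (within the scatter), so among these four compounds only compound 3 stands apart. Nothing available explains why the 2,4-dichlorophenyl group alone gives the higher number.

On these data alone, whether a phenyl ring with a single chlorine would give a number like compound 3 or like compound 4 remains open. So does whether a methyl ester, a primary amide or an amine would match the carboxylic acid on this ring.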